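The compounds below may be only part of what the source reports. "The series", "measured", "known", "first", "only" and "open" are said of these compounds alone.

Three compounds of the series carry numbers in a functional assay for inhibition, with a stated time of 2 h, tested at 0.0625 g/L; a higher number here means more inhibition at the concentration tested (going by the name of the read-out), a lower number less inhibition. Compound 1 `COc1ccc(Nc2cccc3c(C)c(C)sc23)cc1` gives 99.7%, compound 3 `COc1cccc(Nc2cccc3c(C)c(C)sc23)c1` gives 68.9%, and compound 2 `Cc1sc2c(Nc3ccccn3)cccc2c1C` gives 45.8%. Compound 2 stands lowest of the three: compound 3 is nearest, higher by a gap beyond the scatter, and compound 1 is furthest, higher by a gap also beyond the scatter. Compound 4 `Cc1sc2c(Nc3cccnc3)cccc2c1C` differs from compound 2 in one place (pyridin-3-yl in place of pyridin-2-yl on a nitrogen on an aromatic ring). Within the data shown here, no measured pair shows this change, so its effect in this assay is unknown from the data. The step of a number 9.2 percentage points higher from compound 2 to compound 4 (within the scatter) is expected to be small and upward, not clearly beyond the scatter. Pending measurement, compound 4 is estimated at 55%, within 25% to 85%.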

Compound 4, a percentage reported as inhibition, at one concentration (the size of the read-out at that concentration, not a potency): 70.9%
Compound 4: middle estimate off by 15.9 percentage points, on the low side, within the range that was stated.
By their numbers in this assay, from the lowest: compound 2; then compounds 3 and 4 (each within the scatter of the next); then compound 1.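

In this assay, among these compounds, pyridin-3-yl in place of pyridin-2-yl on the nitrogen gives a number 25.1 percentage points higher from compound 2 to compound 4 (beyond the scatter), the first step that can be read. This position therefore responds to how the pyridine ring is joined, even though the heavy atoms, donors and acceptors counted for the group stay the same. No measured information bears on the origin of this step.

Still open, as far as these compounds go, is how pyridin-4-yl on the same nitrogen would read. Also open, from the compounds shown here alone, is whether a methoxy group on the pyridin-3-yl ring would add to this step.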